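From compound 3 to compound 4: one amide group changes

A few compounds are considered here, and "the series" means these few. Any claim that something is new, unique, unknown or untested is made for them only; others in the source may bear on it.

Compound 1 `O=C(CN1CCN(c2nnc(Cc3ccccc3)c3ccccc23)CC1)Nc1ccc(F)c(F)c1` gives 10100 nM
Compound 2 `Cc1ccccc1NC(=O)CN1CCN(c2nnc(Cc3ccccc3)c3ccccc23)CC1` gives "not active" (no number reported)
Compound 3 `O=C(CN1CCN(c2nnc(Cc3ccccc3)c3ccccc23)CC1)Nc1cc(C(F)(F)F)ccc1Cl` gives 89000 nM

All three were tested in a functional assay on A549 cells (Homo sapiens) for cytotoxicity, read by MTT assay, with a stated time of 72 h (a lower number here means a stronger inhibitor, a higher number a weaker inhibitor), and differ only in the group on the amide nitrogen. Of the two compounds with a number, compound 3 stands highest, which makes it the weaker inhibitor, while compound 2 offers no number to compare.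

Compound 4 `O=C(CN1CCN(c2nnc(Cc3ccccc3)c3ccccc23)CC1)Nc1cccc(Br)c1` changes the same place: 3-bromophenyl in place of 2-chloro-5-(trifluoromethyl)phenyl on an amide-type nitrogen gives 3-bromophenyl in place of 2-chloro-5-(trifluoromethyl)phenyl on an amide-type nitrogen. For the measured compounds named here, one measured step bears on this swap, an 8.8-fold higher number from compound 1 to compound 3 (0.95 log units; beyond the scatter), and it is modest but beyond the scatter. A single step is thin evidence. Still, compound 3 sits at the high end of the numbers seen, so a move back towards compound 1 at 10100 nM seems likelier than a further rise in this assay, with a size similar to that step or smaller. Compound 2 is a reminder that no number may come at all.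

The expected change is a 3.6-fold lower number from compound 3 to compound 4 (0.55 log units; beyond the scatter), a fall beyond the scatter but with wide uncertainty. For compound 4 the estimated value is 25000 nM, with an expected range from 7000 nM to 90000 nM as its limits.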

Compound 4, half-maximal inhibitory concentration: "not active" (no number reported)
Compound 4: no number reported; there is nothing to compare the estimate with.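

Compound 4, like compound 2, is reported as "not active" in this assay and has no number, so no new step can be read from compound 3 to compound 4. The compounds shown leave open where compound 4 and compound 2 would stand beside compound 1 and compound 3. No measurement shown accounts for this result.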